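The compounds below may be only part of what the source reports. "The series", "measured", "known", "first", "only" and "open" are said of these compounds alone.

Working notes on the series. Among the compounds with values here, in a functional assay on MNK45 cells (Homo sapiens) for inhibition, read by MTT assay, with a stated time of 48 h (on this read-out lower numbers stand for stronger inhibition and higher numbers for weaker inhibition), compound 1 `Cc1ccc(NC(=O)NC(=O)c2ccc(OCc3cccc(Cl)c3)cc2)cc1-c1nc2ccccc2[nH]1` gives 28000 nM and compound 2 `Cc1ccc(NC(=O)NC(=O)c2ccc(OCc3ccc(C(F)(F)F)cc3)cc2)cc1-c1nc2ccccc2[nH]1` gives 16800 nM; the only measured step, a 1.7-fold lower number from compound 1 to compound 2 (0.22 log units; within the scatter), lies within the scatter, so neither number can be called the better one. Compound 2 therefore stands with the lower of the two numbers in this assay, but its distance from compound 1 carries no weight.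

Compound 3 `Cc1ccc(NC(=O)NC(=O)c2ccc(OCc3ccccc3F)cc2)cc1-c1nc2ccccc2[nH]1` is the next member. The change from compound 2 is 2-fluorophenyl in place of 4-(trifluoromethyl)phenyl on a saturated chain carbon bound to an oxygen on an aromatic ring. Within the data shown here, the one step that bears on it, a 1.7-fold lower number from compound 1 to compound 2 (0.22 log units; within the scatter), also swapped one substituted phenyl for another on the same chain carbon and stayed within the scatter; a second exchange of this kind is expected to do the same, with no step beyond the scatter in this assay, in either direction. The expected step is a 1.2-fold higher number from compound 2 to compound 3 (0.08 log units; within the scatter). Compound 3 is thus expected to give about 20000 nM, with a range from 8000 nM to 50000 nM.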

Compound 3, half-maximal inhibitory concentration: 1830 nM
For compound 3 the middle estimate is 11-fold (1.04 log units) above the measured one; measured number below the stated range.
By their numbers in this assay, from the lowest: compound 3; then compounds 2 and 1 (each within the scatter of the next).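

In this assay, the group on a saturated chain carbon bound to an oxygen on an aromatic ring can move the number well beyond the scatter. This shows for 2-fluorophenyl in place of 4-(trifluoromethyl)phenyl (a 9.2-fold lower number from compound 2 to compound 3 (0.96 log units; beyond the scatter)) and for 2-fluorophenyl in place of 3-chlorophenyl (a 15-fold lower number from compound 1 to compound 3 (1.18 log units; beyond the scatter)), whereas the exchange between the two earlier groups did not separate compound 1 from compound 2. No measurement at hand accounts for the gain seen with 2-fluorophenyl.

Open, from the compounds shown here alone, is whether the gain follows the fluorine itself, its place on the ring, or simply the loss of the larger groups. Comparison with unsubstituted phenyl, 4-fluorophenyl and 2-chlorophenyl on the same chain carbon would separate these readings.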